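A few compounds are considered here, and "the series" means these few. Any claim that something is new, unique, unknown or untested is made for them only; others in the source may bear on it.

Compound 3, `Cn1c(=O)c(S(=O)(=O)c2ccc([N+](=O)[O-])cc2F)cc2cnc(Nc3ccc4[nH]ccc4c3)nc21`, is the reference point here. Within the data shown here, in a functional assay on K562 cells (Homo sapiens) for inhibition, read by trypan blue exclusion, with a stated time of 72 h (on this read-out higher numbers stand for weaker inhibition and lower numbers for stronger inhibition), compound 3 gives 200 nM, the lowest of the three numbers measured so far. Compound 1, `Cn1c(=O)c(S(=O)(=O)c2ccc(F)cc2F)cc2cnc(Nc3cccc4[nH]ccc34)nc21`, carries a 2,4-difluorophenyl sulfone and a differently joined indole; in this assay compound 1 gives 1500 nM, a gap to compound 3 that lies beyond the usual scatter. Compound 2, `Cn1c(=O)c(S(=O)(=O)c2ccccc2)cc2cnc(Nc3ccc4cc[nH]c4c3)nc21`, with an unsubstituted phenyl sulfone, gives 10000 nM in this assay, the weakest result of the set and again well separated from compound 3.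

The step to compound 4, `Cn1c(=O)c(S(=O)(=O)Nc2ccc(F)cc2F)cc2cnc(Nc3ccc4[nH]ccc4c3)nc21`, keeps the core and indole of compound 3 and changes only the group on the sulfonyl sulfur: (2,4-difluorophenyl)amino in place of 2-fluoro-4-nitrophenyl on a sulfonyl sulfur. Among the measured compounds shown here, no measured pair in the set shows this exact change, so the direction can only be judged from the overall spread of the three values.

Compound 4 is expected to inhibit less strongly than compound 3, with an estimated step of a 7.5-fold higher number from compound 3 to compound 4 (0.88 log units; beyond the scatter) in this assay. Compound 4 is estimated at 1500 nM, with a plausible range from 300 nM to 8000 nM; the spread of compound 1 at 1500 nM and compound 2 at 10000 nM shows how wide such a range must be.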

Compound 4, half-maximal inhibitory concentration: 5000 nM
Beside the measured number, compound 4's estimate is 3.3-fold (0.52 log units) below it, within the range that was stated.
By their numbers in this assay, from the lowest: compound 3; then compound 1; then compounds 4 and 2 (each within the scatter of the next).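

In this assay the exchange of 2-fluoro-4-nitrophenyl for (2,4-difluorophenyl)amino on a sulfonyl sulfur gives a 25-fold higher number from compound 3 to compound 4 (1.40 log units; beyond the scatter) with the core and indole held fixed, so the group on this sulfur can by itself move the number well past the scatter. The earlier compounds shown here could not show this: no two of them differed in one place, and their spread could not be assigned to the sulfonyl substituent alone. This single change still alters several things at once, namely the ring substituents and the added nitrogen with its hydrogen-bond donor, and nothing available explains the step or assigns it to one of these parts.

Going by these compounds, it remains open whether the nitrogen link or the ring substituents carry the step, and a 2,4-difluorophenyl sitting directly on the sulfonyl sulfur with this same indole would separate the two. Also open, on these data alone, is how a simple amine or a carboxylic acid on that sulfur would read in this assay with the rest of compound 3 kept unchanged.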